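Replacing the Arylalkylamine of Compound 2 With an Ethylpiperazine

The source may hold more compounds than are shown below. What is called first, only, known or untested is meant among the compounds shown, and "the series" means these compounds.

Among the compounds with values here, compound 2 `COc1ccc(CCCNCc2c(OC)cc(Oc3cccc(Nc4ccccc4)c3)cc2OC)cc1` gives 730 nM in a functional assay on HCT-15 cells (Homo sapiens) for inhibition, read by MTT assay, with a stated time of 72 h (on this read-out lower numbers stand for stronger inhibition and higher numbers for weaker inhibition), and holds the lower of the two numbers measured so far. The other measured compound, compound 1 `COc1cc(Oc2cccc(Nc3ccccc3)c2)cc(OC)c1CNCc1ccc(F)cc1`, gives 3640 nM in this assay. Within the data shown here, the single step between them, a 5.0-fold lower number from compound 1 to compound 2 (0.70 log units; beyond the scatter), came from 2-(4-methoxyphenyl)ethyl in place of 4-fluorophenyl on a saturated chain carbon bound to an amine nitrogen. Compound 3 `CCN1CCN(Cc2c(OC)cc(Oc3cccc(Nc4ccccc4)c3)cc2OC)CC1` differs from compound 2 by 4-ethylpiperazin-1-yl in place of (3-(4-methoxyphenyl)propyl)amino on a saturated chain carbon bound to an aromatic carbon. Among the measured compounds shown here, no measured step tests this exchange directly: the step from compound 1 to compound 2 kept an aromatic ring in the amine part and altered only the chain leading to it, whereas compound 3 keeps no aromatic ring there and instead carries a six-membered non-aromatic ring with two hetero atoms. Because a 5.0-fold lower number from compound 1 to compound 2 (0.70 log units; beyond the scatter) accompanied the larger arylalkyl group, its complete removal in compound 3 is expected to raise the number beyond the scatter, by about a 3.0-fold higher number from compound 2 to compound 3 (0.48 log units; beyond the scatter). Compound 3 is therefore estimated at 2200 nM, with a likely range from 600 nM to 8000 nM.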

Compound 3, half-maximal inhibitory concentration: 5090 nM
Compound 3: the middle estimate sits 2.3-fold (0.36 log units) below what was measured, within the range that was stated.
By their numbers in this assay, from the lowest: compound 2; then compounds 1 and 3 (each within the scatter of the next).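

In this assay, 4-ethylpiperazin-1-yl in place of (3-(4-methoxyphenyl)propyl)amino gives a 7.0-fold higher number from compound 2 to compound 3 (0.84 log units; beyond the scatter) on a saturated chain carbon bound to an aromatic carbon, so the lower number of compound 2 does not carry over to this group, which has a non-aromatic ring with 2 hetero atoms and no hydrogen-bond donor. Measured against (4-fluorobenzyl)amino, the same group gives a 1.4-fold higher number from compound 1 to compound 3 (0.15 log units; within the scatter) within the scatter, so compound 1, with an aromatic ring in its amine part, and compound 3, without one, cannot be told apart, and the presence of that ring alone does not separate the numbers at this place. Nothing given alongside these numbers explains either step.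

The exchange in compound 3 changes the aromatic ring, the hydrogen-bond donor and the chain at once, so the compounds shown do not assign the step to any one of them. From the compounds shown here alone, it also remains open whether a 4-(4-methoxyphenyl)piperazin-1-yl group, which joins the piperazine ring to the aryl group of compound 2, would give a number near that of compound 2 or near that of compound 3.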